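Replacing a benzoxazolyl sulfide with an ethylpiperazine

A few compounds are considered here, and "the series" means these few. Any claim that something is new, unique, unknown or untested is made for them only; others in the source may bear on it.

Measured compounds:
compound 1, `Cn1c(-c2ccc(NC(=O)CSc3nc4cc(Cl)ccc4o3)cc2)nc(-c2ccccc2)c1-c1ccccc1`, 2.5%
compound 2, `Cn1nnnc1SCC(=O)Nc1ccc(-c2nc(-c3ccccc3)c(-c3ccccc3)n2C)cc1`, 34.3%
compound 3, `CN1CCN(CC(=O)Nc2ccc(-c3nc(-c4ccccc4)c(-c4ccccc4)n3C)cc2)CC1`, 2.9%

In a functional assay on MCF7 cells (Homo sapiens) for cytotoxicity, read by MTT assay, with a stated time of 24 h, tested at 1.6 ug/mL (on this read-out higher numbers stand for a stronger effect at the one concentration tested and lower numbers for a weaker effect), compound 1 gives 2.5%, the lowest of the three numbers; compound 3 lies nearest to it, compound 2 furthest. The change to compound 2 was large: a number 31.8 percentage points higher from compound 1 to compound 2 (beyond the scatter). The change to compound 3 stayed flat: a number 0.4 percentage points higher from compound 1 to compound 3 (within the scatter). Between those two, a number 31.4 percentage points lower from compound 2 to compound 3 (beyond the scatter).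

Compound 4, `CCN1CCN(CC(=O)Nc2ccc(-c3nc(-c4ccccc4)c(-c4ccccc4)n3C)cc2)CC1`, has not been measured in this assay. It differs from compound 1 in that (4-ethylpiperazin-1-yl in place of (5-chloro-1,3-benzoxazol-2-yl)sulfanyl on a saturated chain carbon bound to a carbonyl carbon). For the measured compounds named here, the step that bears most directly on it is the one to compound 3, which also put a piperazine on that same saturated chain carbon and stayed within the scatter. The step to compound 2 shows that an exchange at this place can move the number greatly, but the piperazine case did not.

The step from compound 1 to compound 4 is therefore expected to be small, a number 1.5 percentage points higher from compound 1 to compound 4 (within the scatter). Compound 4 is estimated at 4%, with a range from 0% to 16%.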

Compound 4, a percentage reported as activity, at one concentration (the size of the read-out at that concentration, not a potency): 14.6%
Compound 4: middle estimate off by 10.6 percentage points, on the low side; measured number inside the range.
By their numbers in this assay, from the lowest: compounds 1 and 3 (each within the scatter of the next); then compound 4; then compound 2.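

In this assay, the exchange on the saturated chain carbon bound to a carbonyl carbon no longer stays flat once the piperazine carries ethyl: a number 12.1 percentage points higher from compound 1 to compound 4 (beyond the scatter) is the outcome, and the one extra methyl on the saturated chain carbon bound to an amine nitrogen in a ring gives a number 11.7 percentage points higher from compound 3 to compound 4 (beyond the scatter) on its own. The substituent on the piperazine therefore matters here, which compound 3 alone could not show, although a number 19.7 percentage points lower from compound 2 to compound 4 (beyond the scatter) keeps the tetrazolyl sulfide of compound 2 ahead of this amine. Nothing available here explains why the extra methyl changes the number.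

Going by these compounds, whether a propyl group or a 2-hydroxyethyl chain on that piperazine would raise the number further remains open. So does whether a morpholine ring would read like compound 3 or compound 4.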